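Working notes on compound 4 and its measured neighbours

The source may hold more compounds than are shown below. What is called first, only, known or untested is meant among the compounds shown, and "the series" means these compounds.

The series is read in a functional assay on MCF7 cells (Homo sapiens) for cytotoxicity, read by MTT assay, with a stated time of 48 h; on this read-out higher numbers stand for weaker inhibition and lower numbers for stronger inhibition. Compound 1 `CCOC(=O)[C@@H]1C[C@@]23CN(C)C[C@@H](CCC4=C2[C@@H]1CC4=O)C31CC[C@](CC)(OC)OC1` and compound 2 `CC[C@]1(OC)CCC2(CO1)[C@@H]1CCC3=C4[C@H](CC3=O)[C@H](C(=O)OC)C[C@@]42CN(C)C1` share one core and differ only in the ester: methyl in place of hydrogen on a saturated chain carbon bound to an oxygen next to a carbonyl group. Compound 3 `CCC1=CCC2(CO1)[C@@H]1CCC3=C4[C@H](CC3=O)[C@H](C(=O)OC)C[C@@]42CN(C)C1` rests on a different core; how it differs from compound 2 is not broken down here. Compound 4 `COC(=O)[C@@H]1C[C@@]23CN(C)C[C@@H](CCC4=C2[C@@H]1CC4=O)C31CC=C(C(C)C)OC1` is the member still to be measured.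

In this assay compound 1 returns only a limit, > 40000 nM. Compound 2 likewise gives only a limit, > 40000 nM. Compound 3 also stops at a limit, > 40000 nM. All three sit at the limit of > 40000 nM in this assay, at which 3 of the 3 values shown sit, which is why the step that the two limits leave unreadable from compound 2 to compound 1 cannot be sized.

From compound 3 to compound 4 the change is methyl in place of hydrogen on a saturated chain carbon bound to a double-bonded ring carbon and a saturated chain carbon. The group that enters is the same as from compound 2 to compound 1, but the place is not: there the saturated chain carbon was bound to an oxygen next to a carbonyl group, here it is bound to a double-bonded ring carbon and a saturated chain carbon. It is the same kind of change, not the same change.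

With the earlier step unreadable, the step expected in this assay is a step that the limit leaves unreadable from compound 3 to compound 4, taken as essentially flat. This expectation rests on compound 3 standing at the limit > 40000 nM. Compound 4 is expected to come out near 60000 nM, within 30000 nM to 150000 nM, and most probably as a limit once more.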

Compound 4, half-maximal inhibitory concentration: > 40000 nM
Compound 4 was reported as a limit (the forecaster's own chance of this, stated with the estimate: 85%); the middle value is on the limit's open side.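

Compound 4 returns > 40000 nM in this assay, which is a limit and not a number. No step can be read from compound 3 to compound 4, since both compounds stop at a limit: the limit of > 40000 nM in this assay, at which 4 of the 4 values shown sit.

The compounds shown leave open what size the ethyl to isopropyl difference has, and whether any member of this series gives a readable value in this assay.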